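The compounds below may be only part of what the source reports. "The series", "measured", "known", "first", "only" and "open" are said of these compounds alone.

Compound 1, `CCCCCN1C(=O)C/C(=C\c2cccc(C(=O)Nc3ccc(C)cc3)c2)C1=O`, compound 2, `COc1ccc(NC(=O)c2cccc(/C=C3\CC(=O)N(c4ccccc4)C3=O)c2)c(C)c1`, and compound 3, `CCc1cccc(NC(=O)c2cccc(/C=C3\CC(=O)N(c4ccc(C)cc4)C3=O)c2)c1`, have been measured in an ADME assay on SW480 cells (Homo sapiens) for cytotoxicity, read by MTT assay, with a stated time of 72 h; on this read-out higher numbers stand for weaker inhibition and lower numbers for stronger inhibition. For compound 1 the result is only a limit of the assay, > 100000 nM. For compound 2 likewise only a limit of the assay is reported, > 100000 nM. Compound 3 gives 65300 nM, a number just inside the measurable range. Compound 2 therefore stands at the limit with no number of its own, and it shares this position with one of the other two results; the limit of > 100000 nM in this assay, at which 2 of the 3 values shown sit, sums up where most of the values lie. Compound 4, `O=C(Nc1ccc(Cl)cc1)c1cccc(/C=C2\CC(=O)N(c3ccccc3)C2=O)c1`, has not yet been measured. It differs from compound 2 in one place: 4-chlorophenyl in place of 4-methoxy-2-methylphenyl on an amide-type nitrogen. No step between two measured compounds that differ in a single place has been measured, so there is no direct guide to how much a change of this kind in the aryl group on an amide-type nitrogen moves the result. Starting from compound 2 at the limit, the step of an at least 1.1-fold lower number from compound 2 to compound 4 (0.04 log units; that floor lies within the scatter) is expected to lie within the usual scatter. My estimate for compound 4 is 90000 nM, within a range from 40000 nM to 200000 nM, most likely again reported only as a limit.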

Compound 4, half-maximal inhibitory concentration: > 100000 nM
Compound 4 was reported as a limit (the forecaster's own chance of this, stated with the estimate: 60%); middle value at least 1.1-fold (0.04 log units) from the limit.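

Compound 2 and compound 4 are both reported only as limits of the assay, so no step can be read between them. Still open is how much 4-chlorophenyl in place of 4-methoxy-2-methylphenyl on an amide-type nitrogen moves the result in this assay, and most values shown sit at one limit: the limit of > 100000 nM in this assay, at which 3 of the 4 values shown sit.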